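Bromine for Methyl on Two Related Scaffolds

A few compounds are considered here, and "the series" means these few. Any claim that something is new, unique, unknown or untested is made for them only; others in the source may bear on it.

Compound 1 `Cc1ccc(S/C(=C/c2c[nH]c3ccccc23)C(=O)c2ccc(Br)cc2)cc1` and compound 2 `O=C(/C(=C\c1c[nH]c2ccccc12)Sc1ccc(Br)cc1)c1ccc(Br)cc1` share one core; compound 3 `CCOc1ccc(/C=C(\C(=O)c2ccc(Br)cc2)S(=O)(=O)c2ccc(C)cc2)cc1OC` and compound 4 `CCOc1ccc(/C=C(\C(=O)c2ccc(Br)cc2)S(=O)(=O)c2ccc(Br)cc2)cc1OC` share another, and the difference between the two cores is not broken down here. In a functional assay on DU-145 cells (Homo sapiens) for inhibition, read by trypan blue exclusion, with a stated time of 96 h (on this read-out higher numbers stand for weaker inhibition of growth and lower numbers for stronger inhibition of growth), compound 1 gives 10000 nM, and compound 2 gives 1000 nM. The change between them, (bromo in place of methyl on an aromatic carbon), brought a 10-fold lower number from compound 1 to compound 2 (1.00 log units; beyond the scatter). In this assay compound 3 gives 1000 nM, level with compound 2. The same change, (bromo in place of methyl on an aromatic carbon), leads to compound 4, which has not been measured. A lower number is expected for compound 4 because the earlier swap gave a 10-fold lower number from compound 1 to compound 2 (1.00 log units; beyond the scatter). The untold core difference leaves room for a smaller step, so compound 4 is estimated at 300 nM, within 100 nM to 1500 nM. That expectation means a 3.3-fold lower number from compound 3 to compound 4 (0.52 log units; beyond the scatter).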

Compound 4, concentration for 50% growth inhibition: 1000 nM
Compound 4: middle estimate off by 3.3-fold (0.52 log units), on the low side; the range from low to high includes it.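

In this assay, bromo in place of methyl gave no change at the digits printed from compound 3 to compound 4 (within the scatter), so the lower number seen on the core of compound 1 did not reappear on the core of compound 3. In these two pairs, then, the result of this change depends on the core it is made on: the same change on two cores in this assay, a 10-fold lower number (1.00 log units; beyond the scatter) from compound 1 to compound 2 and no change at the digits printed (within the scatter) from compound 3 to compound 4, 10-fold (1.00 log units) apart, beyond the scatter of two such steps This rests on a single pair for each core, and it does not show which part of the cores makes the difference, or why.

The compounds shown leave open how an amine or a carboxylic acid in place of the bromo would behave on either core. They also leave open whether the sulfonyl of compound 4, set against the sulfur of compound 2, matters to this outcome.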